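Thiophene for phenyl at the chain end of compound 1

The source may hold more compounds than are shown below. What is called first, only, known or untested is meant among the compounds shown, and "the series" means these compounds.

Among the measured compounds shown here, compound 1 `O=C(NCCCCCc1ccccc1)n1c(=O)oc2ccccc21` is the weaker of the two measured members: in an assay on HEK293 cells for inhibition of acid ceramidase (Homo sapiens), with a stated time of 10 min (on this read-out higher numbers stand for weaker inhibition and lower numbers for stronger inhibition), compound 1 gives 54 nM, whereas compound 2 `O=C(c1ccc(Cl)cc1)c1ccc2c(c1)oc(=O)n2C(=O)NCCCCc1ccccc1` gives 14 nM in this assay, a gap beyond the scatter. Compound 3 `O=C(NCCCCc1cccs1)n1c(=O)oc2ccccc21` carries thiophen-2-yl in place of benzyl on a saturated chain carbon, four bonds along the chain from an amide-type nitrogen. For the measured compounds named here, no measured pair shows this change, so the step is expected to be small, in either direction or none beyond the scatter, with a slight lean toward a higher number. For compound 3 the estimate in this assay is 65 nM, range 20 nM to 200 nM, meaning an expected step of a 1.2-fold higher number from compound 1 to compound 3 (0.08 log units; within the scatter).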

Compound 3, half-maximal inhibitory concentration: 37 nM
For compound 3 the middle estimate is 1.8-fold (0.24 log units) above the measured one; the measured number falls inside the stated range.
By their numbers in this assay, from the lowest: compound 2; then compounds 3 and 1 (each within the scatter of the next).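

In this assay, among the compounds shown here, the swap of benzyl for thiophen-2-yl gives a 1.5-fold lower number from compound 1 to compound 3 (0.16 log units; within the scatter) and is the first measured change at this position. The chain end therefore takes a five-membered aromatic ring with 1 hetero atom in place of a six-membered aromatic ring of carbon only, with no shift beyond the scatter. No data on hand bear on the reason for this result.

Still open, on these data alone, is how this position responds to an amine or a carboxylic acid at the chain end, or to a longer chain bearing thiophen-2-yl. Also open, as far as these compounds go, is whether thiophen-2-yl gives a similar result on the core of compound 2.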